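The compounds below may be only part of what the source reports. "The series", "measured", "known", "first", "only" and "open" are said of these compounds alone.

Four compounds share one core. Compound 1 `c1ccc(-c2ccc(Cn3nnc4ccccc43)cc2)cc1` gives 7.9 mL/min/g in an ADME assay on microsomes from liver (Homo sapiens) for metabolic stability, tested at 2.5 uM (a higher number here means faster removal of the compound, a lower number slower removal), a high number. Compound 2 `Fc1cc(Cl)ccc1-c1ccc(Cn2nnc3ccccc32)cn1` gives 0.01 mL/min/g in this assay, a far smaller number than compound 1 shows. Compound 3 `Fc1ccccc1-c1ccc(Cn2nnc3ccccc32)cn1` stands nowhere on these numbers: in this assay compound 3 gives "not determined" (no result reported), so its place is not known. Compound 4 `Clc1ccc(-c2ccc(Cn3nnc4ccccc43)cn2)cc1` differs from compound 3 in one place: 4-chlorophenyl in place of 2-fluorophenyl on an aromatic carbon. Among the compounds with values here, no measured step connects the two, so nothing measured tells whether this change moves this assay beyond the scatter or in which direction; the two known values, compound 1 at 7.9 mL/min/g and compound 2 at 0.01 mL/min/g, only frame the range where compound 4 could fall. Compound 4 is expected to give 0.3 mL/min/g, within a range from 0.03 mL/min/g to 3 mL/min/g.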

Compound 4, intrinsic clearance in a liver preparation (reported as CLH), per the amount of preparation that the assay uses: 0.2 mL/min/g
Compound 4: middle estimate off by 1.5-fold (0.18 log units), on the high side; the range from low to high includes it.
By their numbers in this assay, from the lowest: compound 2; then compound 4; then compound 1.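

Hydrogen in place of fluoro on an aromatic carbon gives a 20-fold higher number from compound 2 to compound 4 (1.30 log units; beyond the scatter) in this assay with the rest of the molecule unchanged. Within the data shown here, this is the first measured step between compounds differing in one place, and it shows that this one fluoro alone separates two compounds by more than the scatter. Nothing measured here explains the size of this step. On these data alone, whether a methyl, a methoxy or an amine on that carbon would give a number near that of compound 2 stays open. As far as these compounds go, with no result for compound 3, what the 4-chlorophenyl group does in place of 2-fluorophenyl also stays open.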